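Adding a nitro group to compound 3

This account rests on a few compounds, and the source may have more. Where it says the series, first, only, none or still open, it means among the compounds named here.

Of the compounds shown here, three have been read so far in a functional assay on HO8910 cells (Homo sapiens) for inhibition, read by MTT assay, with a stated time of 24 h, tested at 100 ug/mL; a lower number here means less inhibition of growth, a higher number more inhibition of growth at the concentration tested. Compound 1 (`O=C(CCCCC1CCSS1)Nc1ccc([N+](=O)[O-])c(C(F)(F)F)c1`) gives 47.7%. Compound 2 (`O=C(CCCCC(S)CCS)Nc1cccc(Cl)c1`) is reported as "not active" (no number reported), which leaves no number to compare. Compound 3 (`O=C(CCCCC(S)CCS)Nc1cccc(C(F)(F)F)c1`) gives 34.8%, the lower of the two numbers, and its gap to compound 1 lies beyond the usual scatter.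

The next entry is compound 4 (`O=C(CCCCC(S)CCS)Nc1ccc([N+](=O)[O-])c(C(F)(F)F)c1`). Relative to compound 3, it has nitro in place of hydrogen on an aromatic carbon, ortho to a trifluoromethyl group and para to a large group: nitro in place of hydrogen on an aromatic carbon. Among the compounds with values here, no pair of measured compounds isolates this change, so the evidence is indirect. Within the data shown here, the only measured compound with a nitro group is compound 1, at 47.7%, which points weakly upward. The rest of its structure is not the same as in compound 4, and that limits how far the comparison can be carried.

A modest rise in this assay is expected, with a number 7.2 percentage points higher from compound 3 to compound 4 (within the scatter) possibly staying within the scatter. For compound 4, the estimated value is 42%, with an expected range of 28% to 58%.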

Compound 4, percent growth inhibition at one concentration: 92.7%
Beside the measured number, compound 4's estimate is 50.7 percentage points below it; the measured number lies above the stated range.
By their numbers in this assay, from the lowest: compound 3; then compound 1; then compound 4.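

In this assay, within the data shown here, nitro in place of hydrogen on an aromatic carbon, ortho to a trifluoromethyl group and para to a large group, gives a number 57.9 percentage points higher from compound 3 to compound 4 (beyond the scatter) and so provides the first pair that isolates this position, with a large step in the direction of more inhibition of growth. The nitro group does not set the level on its own, since compound 1 and compound 4 both carry it and the open group of 5 heavy atoms in place of the five-membered ring with 2 hetero atoms gives a number 45 percentage points higher from compound 1 to compound 4 (beyond the scatter) as a second large step, so the aromatic substituent and the end of the chain both bear on the read-out. No measurement at hand bears on the reason for either step.

As far as these compounds go, whether the rise is specific to nitro remains open, as a nitrile or an amine at the same place would be needed to tell. Also open is whether the nitro step depends on the trifluoromethyl group ortho to it or on the open chain end, and how the order of these compounds would hold at other concentrations.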